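The source may hold more compounds than are shown below. What is called first, only, known or untested is meant among the compounds shown, and "the series" means these compounds.

Measured so far:

- compound 1, `CC1=C(C(=O)Nc2ccc(Br)cc2)C(c2ccc(Cl)cc2Cl)N=C(SCc2ccccc2)N1`: in a functional assay on the whole organism (artery, strain albino) with Rattus norvegicus as the target, with a stated time of 300 min, at a dose of 10 mg/kg by the oral route (a lower number here means less inhibition, a higher number more inhibition at the dose given (going by the name of the read-out)), compound 1 gives 22.1%
- compound 2, `COc1ccc(C2N=C(SCc3ccccc3)NC(C)=C2C(=O)Nc2ccc(Br)cc2)cc1`: in this assay compound 2 gives 16.4%

On these two numbers compound 2 sits within the scatter of compound 1: the step of a number 5.7 percentage points lower from compound 1 to compound 2 (within the scatter) is too small to tell the two apart, so neither number can be called the higher or the lower one.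

Compound 3, `COc1ccc(C2N=C(SCc3ccc(F)cc3)NC(C)=C2C(=O)Nc2ccc(Br)cc2)cc1`, differs from compound 2 in a single place: fluoro in place of hydrogen on an aromatic carbon.

Among the measured compounds shown here, only one measured step is available, a number 5.7 percentage points lower from compound 1 to compound 2 (within the scatter), and it concerns the group on the saturated ring carbon, a different part of the shared core; it stayed within the scatter. For the measured compounds named here, no measured step exchanges hydrogen for fluoro on an aromatic carbon, so the data give no direct guide for this change. With nothing pointing either way, the plain expectation is a step within the scatter. The step expected from compound 2 to compound 3 in this assay is therefore a number 0.6 percentage points higher from compound 2 to compound 3 (within the scatter). For compound 3 the expected value in this assay is 17%, estimated to lie between 6% and 29%.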

Compound 3, a percentage reported as inhibition, in the whole organism at one dose (the size of the read-out at that dose, not a potency): 26.2%
For compound 3 the middle estimate is 9.2 percentage points below the measured one; low and high end bracket the measured number.
By their numbers in this assay, from the lowest: compounds 2, 1 and 3 (each within the scatter of the next).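

Among the compounds shown here, the benzylsulfanyl group had stayed the same in the earlier compounds, so this is the first measured change at that end of the molecule, as the step between compound 1 and compound 2 concerned only the group on the saturated ring carbon. In this assay, putting fluoro in place of hydrogen on the benzyl ring gives a number 9.8 percentage points higher from compound 2 to compound 3 (within the scatter), so the phenyl and 4-fluorophenyl forms of this group cannot be told apart in this read-out, with 4-methoxyphenyl held constant on the saturated ring carbon. Nothing available explains how this single atom acts at this position, and the result alone gives no cause.

The compounds shown leave open whether fluoro on the benzyl ring would give a similar step when paired with the 2,4-dichlorophenyl group of compound 1, since the two changes appear together in no compound here. They also leave open whether a larger change at the same ring carbon, such as an amine, a carboxylic acid or a longer chain in place of fluoro, would move the inhibition beyond the usual scatter.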